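The compounds below may be only part of what the source reports. "The series", "measured", "known", "first", "only" and "open" are said of these compounds alone.

Working notes on the series, followed in a physicochemical assay for solubility, read by LC-MS, in phosphate buffer, with a stated time of 24 h, at pH 7.4; a lower number here means a less soluble compound, a higher number a more soluble compound. Compound 3 (`O=C(Nc1cnc(NCc2c(F)ccc3c2CCO3)n2cnnc12)c1cccnc1`) gives 12000 nM. Compound 1 (`Fc1ccc2c(c1CNc1ncc(Oc3ccccc3)c3nncn13)CCO2`) gives 8000 nM, and the two lie within the scatter of each other. Compound 2 (`CN(c1ccccc1)c1cnc(NCc2c(F)ccc3c2CCO3)n2cnnc12`) reads < 2000 nM, which is a limit of the assay and not a number.

The next compound is compound 4 (`O=C1CCCN1c1cnc(NCc2c(F)ccc3c2CCO3)n2cnnc12`), which carries 2-oxopyrrolidin-1-yl in place of ((pyridin-3-yl)carbonyl)amino on an aromatic carbon.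

Three measured steps change the group at this same place. The step of a 1.5-fold higher number from compound 1 to compound 3 (0.18 log units; within the scatter) stayed within the scatter. The steps of an at least 4.0-fold lower number from compound 1 to compound 2 (0.60 log units; beyond the scatter) and an at least 6.0-fold higher number from compound 2 to compound 3 (0.77 log units; beyond the scatter) went beyond it, and both rest on the limit of compound 2. Two of the three groups tried here therefore read alike, with compound 2 the exception, and no step beyond the scatter is expected in either direction for the new group. The expected step is a 1.3-fold lower number from compound 3 to compound 4 (0.12 log units; within the scatter). For compound 4 the estimate is 9000 nM, with an expected range from 3000 nM to 25000 nM.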

Compound 4, solubility: 640000 nM
Compound 4: the middle estimate sits 71-fold (1.85 log units) below what was measured; measured number outside the range, above it.
By their numbers in this assay, from the lowest: compounds 1 and 3 (each within the scatter of the next); then compound 4. At a limit, below all of these: compound 2.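

Position note: the group on this aromatic carbon can move the number in this assay far beyond anything compound 1 and compound 3 suggested, with a 53-fold higher number from compound 3 to compound 4 (1.73 log units; beyond the scatter) and an 80-fold higher number from compound 1 to compound 4 (1.90 log units; beyond the scatter). Both compound 3 and compound 4 carry a carbonyl in the group at this place, so a carbonyl alone does not set the reading; the change from compound 3 also removes the six-membered aromatic ring and the hydrogen-bond donor and brings in a five-membered non-aromatic ring. The step of an at least 320-fold higher number from compound 2 to compound 4 (2.50 log units; beyond the scatter) rests on the limit of compound 2, which is a limit of the assay and not a number: the limit of < 2000 nM in this assay, at which 1 of the 4 values shown sits.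

Which feature of 2-oxopyrrolidin-1-yl carries the step remains open. Plain pyrrolidin-1-yl, the six-membered 2-oxopiperidin-1-yl and an open-chain acetamide would begin to separate the ring from its carbonyl.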